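Shortening an Alkyl Group on a Ring Amine

A few compounds are considered here, and "the series" means these few. Any claim that something is new, unique, unknown or untested is made for them only; others in the source may bear on it.

Measured compounds:
compound 1 `COc1ccc(F)c(-c2ccc3c(NC(=O)c4ccc(N5CCCN(C)CC5)cc4)n[nH]c3c2)c1F`: 102 nM
compound 2 `CCN1CCN(c2ccc(C(=O)Nc3n[nH]c4cc(-c5c(F)ccc(OC)c5F)ccc34)cc2)CC1`: 77.4 nM

Both compounds were tested in a functional assay on SNU-16 cells (Homo sapiens) for antiproliferative activity, read by CCK-8 assay, with a stated time of 72 h; on this read-out lower numbers stand for stronger inhibition and higher numbers for weaker inhibition. Compound 2 `CCN1CCN(c2ccc(C(=O)Nc3n[nH]c4cc(-c5c(F)ccc(OC)c5F)ccc34)cc2)CC1` gives 77.4 nM, the lowest of the two numbers; compound 1 sits close by, and the step of a 1.3-fold lower number from compound 1 to compound 2 (0.12 log units; within the scatter) stays within the scatter, so no real order between them can be claimed.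

Compound 3 `COc1ccc(F)c(-c2ccc3c(NC(=O)c4ccc(N5CCN(C)CC5)cc4)n[nH]c3c2)c1F` differs from compound 2 by hydrogen in place of methyl on a saturated chain carbon bound to an amine nitrogen in a ring. Within the data shown here, the only measured step that bears on this kind of change is a 1.3-fold lower number from compound 1 to compound 2 (0.12 log units; within the scatter), where the whole ring amine and its alkyl group were swapped with no effect beyond the scatter. A change confined to the alkyl group alone seems unlikely to do more. Compound 3 is therefore expected to land close to compound 2, with a step of a 1.2-fold higher number from compound 2 to compound 3 (0.07 log units; within the scatter) that stays within the scatter. The estimate for compound 3 is 90 nM, with a range from 40 nM to 200 nM.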

Compound 3, half-maximal inhibitory concentration: 35.6 nM
For compound 3 the middle estimate is 2.5-fold (0.40 log units) above the measured one, outside the stated range (below it).
By their numbers in this assay, from the lowest: compound 3; then compounds 2 and 1 (each within the scatter of the next).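

In this assay the alkyl group on the ring amine turns out to matter: going from 4-ethylpiperazin-1-yl to 4-methylpiperazin-1-yl gives a 2.2-fold lower number from compound 2 to compound 3 (0.34 log units; beyond the scatter) and this modest step is a readable one, unlike the earlier swap of ring amines. The ring amine itself also counts when both compounds carry the same methyl group, since 4-methylpiperazin-1-yl in place of 4-methyl-1,4-diazepan-1-yl gives a 2.9-fold lower number from compound 1 to compound 3 (0.46 log units; beyond the scatter) and so the earlier step alone gave no sign of a real difference among these rings. Nothing measured here explains why these changes go with lower numbers.

Going by these compounds, whether the trend continues to an unsubstituted piperazin-1-yl ring, with only a hydrogen on that nitrogen, remains open. So does the effect of a longer chain such as propyl, or of a morpholine ring in place of the piperazine.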